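Ring-epimer of an ethyl iminocyclitol against fucosidase

The source may hold more compounds than are shown below. What is called first, only, known or untested is meant among the compounds shown, and "the series" means these compounds.

Working notes on a small set of iminosugar-type compounds. In an assay on isolated protein for inhibition of tissue alpha-L-fucosidase (Bos taurus), tested at 1000 uM (on this read-out lower numbers stand for less inhibition and higher numbers for more inhibition at the one concentration tested (going by the name of the read-out)), the propyl-bearing compound 1 `CCC[C@@H]1NC[C@@H](O)[C@@H](O)[C@H](O)[C@H]1O` gives 0%, while the ethyl-bearing compound 2 `CC[C@H]1NC[C@@H](O)[C@@H](O)[C@H](O)[C@H]1O` gives 36.7%. For the measured compounds named here, compound 2 thus stands highest of the two numbers measured so far, and its gap to compound 1 lies beyond the scatter. Going by the values given here, the two differ in both chain length and drawn configuration at the chain-bearing ring carbon, so no single-change step is available from them.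

Compound 3 `CC[C@@H]1NC[C@@H](O)[C@@H](O)[C@H](O)[C@H]1O` is the next case. Compared with compound 2: the two compounds have the same atoms and bonds and differ only in configuration as drawn: 1 of 5 stereo elements differ; a stereocentre at a saturated ring carbon is drawn R in compound 2 and S in compound 3. The drawn configuration of compound 3 at that centre matches that of compound 1, whose value in this assay is low. On that basis the expected step from compound 2 to compound 3 is a drop, a number 26.7 percentage points lower from compound 2 to compound 3 (beyond the scatter), likely beyond the scatter. Compound 3 is estimated at 10% in this assay, within a range from 0% to 35%.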

Compound 3, a percentage reported as inhibition, at one concentration (the size of the read-out at that concentration, not a potency): 37.2%
Estimate against measurement, compound 3: 27.2 percentage points below; measured number outside the range, above it.
By their numbers in this assay, from the lowest: compound 1; then compounds 2 and 3 (each within the scatter of the next).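

In this assay, the change of drawn configuration at this saturated ring carbon gives a number 0.5 percentage points higher from compound 2 to compound 3 (within the scatter), so with an ethyl chain this centre does not separate the two compounds: the fact that compounds 2 and 3 differ only in the configuration as drawn

With the configuration at that centre held the same, hydrogen in place of methyl on the saturated chain carbon gives a number 37.2 percentage points higher from compound 1 to compound 3 (beyond the scatter). On this single pair, the low value of compound 1 goes with the propyl chain and not with the drawn configuration it shares with compound 3.

Still open, as far as these compounds go, is whether a propyl chain drawn the other way at this centre would also read low, and whether the insensitivity to configuration holds for a methyl or a butyl chain. A reading at one concentration also leaves open any difference in potency between compound 2 and compound 3.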